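The compounds below may be only part of what the source reports. "The series", "measured", "known", "first", "only" and "open" are said of these compounds alone.

Working notes on the series. Going by the values given here, compound 1 `Cc1n[nH]c(C(=O)O)c1Cc1cccc(-c2cccc(F)c2)c1` is the stronger of the two measured members: in an assay on isolated protein for inhibition of 2-Hydroxyacid oxidase 2 (Homo sapiens), tested at 1 uM (a higher number here means a stronger effect of the compound at the concentration tested, a lower number a weaker effect), compound 1 gives 20%. The only comparator, compound 2 `Cc1n[nH]c(C(=O)O)c1Cc1ccc(C#N)cc1`, gives in this assay a read-out of 0%, a gap that lies beyond the usual scatter. The two differ at more than one place, so their values are stated side by side without a step between them.

Compound 3 `Cc1n[nH]c(C(=O)O)c1Cc1cccc(OC(F)(F)F)c1` is the next member to be measured in this assay. Relative to compound 1 the change is trifluoromethoxy in place of 3-fluorophenyl on an aromatic carbon, on the same shared core. Among the compounds with values here, no measured pair isolates this change, so the expected step rests only on the two numbers above. A modest loss is expected, with the step from compound 1 to compound 3 estimated at a number 12 percentage points lower from compound 1 to compound 3 (beyond the scatter). For compound 3 in this assay the estimate is 8%, within a range from 0% to 22%.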

Compound 3, a percentage reported as inhibition, at one concentration (the size of the read-out at that concentration, not a potency): 2%
Estimate against measurement, compound 3: 6 percentage points above; the range from low to high includes it.
By their numbers in this assay, from the lowest: compounds 2 and 3 (each within the scatter of the next); then compound 1.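

Trifluoromethoxy in place of 3-fluorophenyl gives a number 18 percentage points lower from compound 1 to compound 3 (beyond the scatter) in this assay, which shows that the read-out responds to the group at this place on the shared core, something the earlier pair, differing at more than one place, could not show. The change takes away a six-membered aromatic ring of carbon only and brings in a hydrogen-bond acceptor, and these differences arrive together in this single step, so neither can be singled out. No measurement at hand explains the loss.

Open, going by these compounds, is how much of the read-out of compound 1 depends on the ring and how much on its fluorine, a question that an unsubstituted phenyl at this place would address. Also open, on these data alone, is whether a methoxy group or a pyridine ring here would behave like trifluoromethoxy or like 3-fluorophenyl.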